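This account rests on a few compounds, and the source may have more. Where it says the series, first, only, none or still open, it means among the compounds named here.

Series notes. Compound 1 `O=C(Nc1cc(-c2ccccc2)nn1-c1ccccc1)c1ccc(OC(F)(F)F)cc1` gives 18 nM in a functional assay on cells for positive allosteric modulation of metabotropic glutamate receptor 5 (Rattus norvegicus), read by calcium flux; on this read-out higher numbers stand for an effect only at larger amounts of compound and lower numbers for an effect already at smaller amounts; compound 2 `O=C(Nc1cc(-c2ccccc2)nn1-c1ccccc1)c1ccc([N+](=O)[O-])cc1` gives 10.7 nM, and the step of a 1.7-fold lower number from compound 1 to compound 2 (0.23 log units; within the scatter) leaves the two undistinguished, so compound 2 stands at the lower of two numbers that lie within the scatter of each other. The next member, compound 3 `O=C(CC1CCCC1)Nc1cc(-c2ccccc2)nn1-c1ccccc1`, differs from compound 2 by cyclopentylmethyl in place of 4-nitrophenyl on a carbonyl carbon. Going by the values given here, no measured step touches this kind of change; the single known step alters only a substituent on the aromatic ring that is now removed, so it gives no guidance. For compound 3 the expectation is a step toward higher numbers, a 19-fold higher number from compound 2 to compound 3 (1.27 log units; beyond the scatter), with wide uncertainty. The estimate for compound 3 is 200 nM, expected between 40 nM and 2000 nM.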

Compound 3, half-maximal effective concentration: 350 nM
Estimate against measurement, compound 3: 1.8-fold (0.24 log units) below, and the stated range covers the measured number.
By their numbers in this assay, from the lowest: compounds 2 and 1 (each within the scatter of the next); then compound 3.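

In this assay cyclopentylmethyl in place of 4-nitrophenyl on a carbonyl carbon gives a 33-fold higher number from compound 2 to compound 3 (1.51 log units; beyond the scatter) and thus shows that this position, unaffected beyond the scatter by the earlier substituent exchange on the aromatic ring, does respond when the whole group is replaced. The step cannot separate the loss of the aromatic ring from the loss of the nitro group. No measured evidence bears on the cause of this step.

On these data alone, whether a plain phenyl or a cyclohexyl on this carbonyl carbon would read like compound 2 or like compound 3 remains open. Also open, as far as these compounds go, is how an amine or a carboxylic acid on the aromatic ring would read.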